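The source may report more compounds than this note shows. Statements on the series, on what has been measured and on what is new or still open speak of the compounds shown alone.

Measured so far:

- compound 1 `C[C@H]1CC[C@@H]2[C@@H](OC(=O)[C@]23CC(c2ccccc2F)=NO3)[C@]2(C)C(=O)C=C[C@@]12O` — 24000 nM
- compound 2 `Cc1ccccc1C1=NO[C@]2(C1)C(=O)O[C@@H]1[C@H]2CC[C@H](C)[C@]2(O)C=CC(=O)[C@@]12C` — 12000 nM
- compound 3 `Cc1ccc(C2=NO[C@]3(C2)C(=O)O[C@@H]2[C@H]3CC[C@H](C)[C@]3(O)C=CC(=O)[C@@]23C)cc1` — 14000 nM

All three numbers come from a functional assay on DU-145 cells (Homo sapiens) for cytotoxicity, read by sulforhodamine B assay, with a stated time of 48 h; a lower number here means a stronger inhibitor, a higher number a weaker inhibitor. The three compounds share one core and differ only in the aromatic ring hanging from it. Compound 2 and compound 3 are built from the same atoms joined differently: 4-methylphenyl in place of 2-methylphenyl on a carbon with a double bond to nitrogen. In this assay that rearrangement gives a 1.2-fold higher number from compound 2 to compound 3 (0.07 log units; within the scatter), so the two cannot be told apart. Compound 1 differs from compound 2 in a single atom: fluoro in place of methyl on an aromatic carbon. That swap gives a 2.0-fold higher number from compound 2 to compound 1 (0.30 log units; within the scatter), again too small to count as a real change.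

Compound 4 `C[C@H]1CC[C@@H]2[C@@H](OC(=O)[C@]23CC(c2ccc(F)cc2)=NO3)[C@]2(C)C(=O)C=C[C@@]12O` has not yet been measured. It differs from compound 3 by fluoro in place of methyl on an aromatic carbon. For the measured compounds named here, this is the same kind of change as the one from compound 2 to compound 1, but not the same: there the fluoro sits ortho to a large group, here it sits para to a large group. Going by the values given here, no measured pair shows what that difference in place does on this core.

Among the compounds with values here, for compound 4 a step of a 1.4-fold higher number from compound 3 to compound 4 (0.15 log units; within the scatter) is expected, because a 2.0-fold higher number from compound 2 to compound 1 (0.30 log units; within the scatter) is the only measured example of this swap and it stayed within the scatter. Compound 4 is therefore estimated at 20000 nM, with a likely range from 8000 nM to 50000 nM.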

Compound 4, half-maximal inhibitory concentration: 13000 nM
The estimate for compound 4 lay 1.5-fold (0.19 log units) above the measured number; measured number inside the range.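

In this assay, methyl to fluoro on the aromatic ring gives a 1.1-fold lower number from compound 3 to compound 4 (0.03 log units; within the scatter), and the two other new steps, a 1.1-fold higher number from compound 2 to compound 4 (0.03 log units; within the scatter) and a 1.8-fold lower number from compound 1 to compound 4 (0.27 log units; within the scatter), are just as small, so compound 4 cannot be told apart from compound 1, compound 2 or compound 3. Set side by side, the two examples of the swap do not differ, so in this series the change carries from one core to the other with no detectable difference: the same change on two cores in this assay, a 2.0-fold higher number (0.30 log units; within the scatter) from compound 2 to compound 1 and a 1.1-fold lower number (0.03 log units; within the scatter) from compound 3 to compound 4, 2.2-fold (0.33 log units) apart, within the scatter of two such steps. For the compounds shown here, this does not show that the swap has a real effect that transfers, since neither example moves beyond the scatter; two steps that are both too small to read agree easily, so this is a weak test, and it rests on only two pairs.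

On these data alone, every compound here carries only a methyl or a fluoro on the aromatic ring, so it remains open whether an amine, a carboxylic acid or a longer chain on that ring would move the number beyond the scatter. A step of that size would be needed to test properly whether a change on this ring carries the same effect from one core to another.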